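This account rests on a few compounds, and the source may have more. Where it says the series, first, only, none or still open, it means among the compounds named here.

Among the compounds with values here, in an ADME assay on microsomes from liver (Homo sapiens) for metabolic stability, read by LC-MS, with a stated time of 30 min, tested at 0.5 uM (on this read-out higher numbers stand for a more stable compound and lower numbers for a less stable compound), three compounds sharing one core have numbers so far. Compound 1 `c1ccc(-c2cc(-c3csc(N=C4NCCCN4)n3)cs2)cc1` gives 70%, compound 2 `c1ccc(-n2ccc(-c3csc(N=C4NCCCN4)n3)n2)cc1` gives 38%, and compound 3 `Oc1ccc(-c2nc(-c3csc(N=C4NCCCN4)n3)cs2)cc1` gives 86%. That is the highest of the three, and its gaps to both others lie beyond the scatter. Compound 4 `Oc1ccccc1-c1nc(-c2csc(N=C3NCCCN3)n2)cs1` carries 2-hydroxyphenyl in place of 4-hydroxyphenyl on an aromatic carbon. Within the data shown here, no measured pair differs in one place, so the data give no direct guide to this change. Compound 3 stands high at 86%, leaving little room upward. A small fall within the scatter is expected, an estimated a number 8 percentage points lower from compound 3 to compound 4 (within the scatter). For compound 4 the estimated value is 78%, with an expected range of 58% to 92%.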

Compound 4, percent of the compound remaining: 30%
Estimate against measurement, compound 4: 48 percentage points above; measured number outside the range, below it.
By their numbers in this assay, from the lowest: compounds 4 and 2 (each within the scatter of the next); then compound 1; then compound 3.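

In this assay, 2-hydroxyphenyl in place of 4-hydroxyphenyl on this aromatic carbon gives a number 56 percentage points lower from compound 3 to compound 4 (beyond the scatter), so the read-out at this position can change sharply even when the atoms stay the same and only their joining differs. The two groups have identical counts of heavy atoms, donors and acceptors, so those counts do not separate compound 3 from compound 4. Nothing available accounts for this step. From the compounds shown here alone, it remains open whether an amine or a methoxy group in place of the hydroxyl of compound 4 would give a similar number, and whether this change would have the same effect on a different core.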